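A ring exchange from compound 2 to compound 3

The source may hold more compounds than are shown below. What is called first, only, known or untested is meant among the compounds shown, and "the series" means these compounds.

Of the compounds shown here, two built on a shared core have been measured in a physicochemical assay for lipophilicity, using the shake flask method, measured as octanol-water partition, at pH 7.4; a higher number here means a more lipophilic compound, a lower number a more polar compound. Compound 1 (`CC(C)n1cc(-c2ccnc3[nH]c(C4CCN(CC(=O)N5CCCC5)CC4)cc23)ccc1=O`) gives 2.1, and compound 2 (`CC(C)n1cc(-c2ccnc3[nH]c(C4CCN(CC(=O)N(C)C)CC4)cc23)cnc1=O`) gives 0.4. Compound 2 therefore holds the lower of the two numbers, and its gap to compound 1 lies beyond the scatter. The two differ in more than one place, so their gap does not isolate any single change.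

Compound 3 (`CC(C)n1cc(-c2ccnc3[nH]c(C4CCN(CC(=O)N(C)C)CC4)cc23)ccc1=O`) keeps the amide of compound 2 but exchanges one group: a group of 10 heavy atoms (8 carbon, 1 nitrogen, 1 oxygen; one six-membered aromatic ring with 1 hetero atom) in place of a group of 10 heavy atoms (7 carbon, 2 nitrogen, 1 oxygen; one six-membered aromatic ring with 2 hetero atoms), on an aromatic carbon. The exchange takes place on an aromatic carbon of a six-membered aromatic ring with 1 nitrogen, opposite the ring nitrogen. Among the compounds with values here, no measured step shows this change alone, but a rise beyond the scatter in this assay is expected. That expectation rests on compound 1, which bears the entering group and gives 2.1, although its amide differs from that of compound 3. The expected step is a number 1.30 log units higher from compound 2 to compound 3 (beyond the scatter). For compound 3 the estimated value is 1.7, within an expected range from 1.3 to 2.1.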

Compound 3, distribution coefficient: 1.9
Compound 3: middle estimate off by 0.20 log units, on the low side; low and high end bracket the measured number.
By their numbers in this assay, from the lowest: compound 2; then compounds 3 and 1 (each within the scatter of the next).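

Within the data shown here, with the dimethylamino amide held constant, the ring exchange on the aromatic carbon opposite the ring nitrogen gives in this assay a number 1.50 log units higher from compound 2 to compound 3 (beyond the scatter) and so provides the first reading of this change on its own. The other single change, dimethylamino in place of pyrrolidin-1-yl on a carbonyl carbon, gives a number 0.20 log units lower from compound 1 to compound 3 (within the scatter) and therefore shows no separable difference between these two amides when the ring with 1 hetero atom is present. The compounds shown offer no measurement that explains the size of the ring exchange step.

The compounds shown leave open whether the same ring exchange would give a step of similar size with pyrrolidin-1-yl on the carbonyl carbon, or whether its size depends on the amide present. They also leave open where this assay would place a compound with morpholin-4-yl on that carbonyl carbon, or one with a methoxy group or a fluorine atom added to the entering ring.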